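Swapping a Dimethylamino Chain for a Piperidine Ring

The compounds below may be only part of what the source reports. "The series", "measured", "known", "first", "only" and "open" are said of these compounds alone.

Compound 2 `CN(C)CCCn1c(=O)n(C2OC(CO)[C@@H](O)[C@H]2O)c2nc(N)nc(O)c21` gives the higher of the two responses recorded so far: in a functional assay on the whole organism (B cells) with Mus musculus as the target (a lower number here means a smaller maximal response, a higher number a larger maximal response), compound 2 reaches 83%, a gap well beyond the usual scatter from compound 1 `Cn1c(=O)n2c3c1c(=O)nc(N)n3CC1OC2[C@H](O)[C@@H]1O`, which in this assay reaches only 9%. Compound 3 `Nc1nc(O)c2c(n1)n(C1OC(CO)[C@@H](O)[C@H]1O)c(=O)n2CCN1CCCCC1` differs from compound 2 in one place: piperidin-1-yl in place of (dimethylamino)methyl on a saturated chain carbon, two bonds along the chain from an aromatic nitrogen. Among the compounds with values here, no pair of measured compounds isolates such a change, so the expected step is a small one, in either direction or none beyond the scatter, as a number 8 percentage points lower from compound 2 to compound 3 (within the scatter) shows. Compound 3 is expected to give about 75% in this assay, between 50% and 95%.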

Compound 3, largest response reached (reported as maximal response), in percent of the reference or control that the assay uses: 0%
The estimate for compound 3 lay 75 percentage points above the measured number; the measured number lies below the stated range.
By their numbers in this assay, from the lowest: compounds 3 and 1 (each within the scatter of the next); then compound 2.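

Within the data shown here, this is the first comparison here in which only one place changes, and it shows that this chain position is far from indifferent to the amine it carries: piperidin-1-yl in place of (dimethylamino)methyl gives a number 83 percentage points lower from compound 2 to compound 3 (beyond the scatter) in this assay. Compound 3 also lands within the scatter of compound 1, whose core differs. No measurement shown accounts for the drop. The same change can be read as 3-(dimethylamino)propyl to 2-(piperidin-1-yl)ethyl, so the ring and the shorter chain remain unseparated. A 2-(dimethylamino)ethyl or 3-(piperidin-1-yl)propyl group would tell them apart.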